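Furan-2-yl in place of thiophen-2-yl: compound 4

The source may report more compounds than this note shows. Statements on the series, on what has been measured and on what is new or still open speak of the compounds shown alone.

Within the data shown here, compound 3 `CC1=C(C(=O)OC(C)C)C(c2cccs2)N/C(=N/C#N)N1` gives 27% in an assay on HeLa cells for displacement of a labelled ligand from adenosine receptor A3 (Homo sapiens), with a stated time of 180 min, tested at 1 uM (on this read-out lower numbers stand for less inhibition and higher numbers for more inhibition at the one concentration tested (going by the name of the read-out)), the highest of the three numbers so far; the nearest is compound 2 `CC1=C(C(=O)OC(C)C)C(C2CCCC2)N/C(=N/C#N)N1` with 3%, the furthest compound 1 `CC1=C(C(=O)OC(C)C)[C@H](c2ccco2)N/C(=N/C#N)N1` with 1%, both gaps beyond the scatter. Among the measured compounds shown here, the only measured step that bears on the question, thiophen-2-yl in place of cyclopentyl, was a number 24 percentage points higher from compound 2 to compound 3 (beyond the scatter), a modest rise. Compound 4 `CC1=C(C(=O)OC(C)C)C(c2ccco2)N/C(=N/C#N)N1` differs from compound 3 by furan-2-yl in place of thiophen-2-yl on a saturated ring carbon. For the measured compounds named here, no measured step swaps the two five-membered aromatic rings against each other directly. Compound 1, however, already carries furan-2-yl, drawn with a fixed configuration, and its 1% lies far under the number for compound 3. On that showing the step from thiophen-2-yl to furan-2-yl is expected to run downward, a number 19 percentage points lower from compound 3 to compound 4 (beyond the scatter), beyond the scatter. Compound 4 is therefore estimated at 8%, with a range from 0% to 25%.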

Compound 4, a percentage reported as inhibition, at one concentration (the size of the read-out at that concentration, not a potency): 4%
For compound 4 the middle estimate is 4 percentage points above the measured one, and the stated range covers the measured number.
By their numbers in this assay, from the lowest: compounds 1, 2 and 4 (each within the scatter of the next); then compound 3.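

In this assay, the direct swap of the five-membered aromatic ring on the saturated ring carbon gives a number 23 percentage points lower from compound 3 to compound 4 (beyond the scatter), so the rise seen with thiophen-2-yl does not carry over to furan-2-yl. Furan-2-yl in place of cyclopentyl gives a number 1 percentage points higher from compound 2 to compound 4 (within the scatter), which leaves thiophen-2-yl as the only one of the three groups at this position that separates from the others. Going from the drawn configuration to none gives a number 3 percentage points higher from compound 1 to compound 4 (within the scatter), so the two drawings do not separate here, and this pair says nothing further about the ring itself: the fact that one of compounds 1 and 4 is drawn with a defined configuration and the other without, at the place where they differ.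

On these data alone, whether the rise with thiophen-2-yl is tied to its sulfur remains open. Also open, as far as these compounds go, are how phenyl, a longer alkyl chain or an aminomethyl group would read on this carbon, and how each single configuration of the thiophen-2-yl compound would read.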